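This account rests on a few compounds, and the source may have more. Where it says the series, first, only, none or still open, it means among the compounds named here.

Measured compounds:
compound 1, `CC(C)NS(=O)(=O)NC(=O)Nc1c(C(C)C)cccc1C(C)C`, 18000 nM
compound 2, `CC(C)c1cccc(C(C)C)c1NC(=O)NS(=O)(=O)N1CCCC1`, 15000 nM
compound 3, `C=CCN(CC=C)S(=O)(=O)NC(=O)Nc1c(C(C)C)cccc1C(C)C`, 2700 nM

All three were tested in an assay on liver for inhibition of sterol O-acyltransferase 1 (Rattus norvegicus), using microsomes; a higher number here means a weaker inhibitor, a lower number a stronger inhibitor. Compound 3 has the lowest number of the three; its nearest neighbour is compound 2, and the step of a 5.6-fold lower number from compound 2 to compound 3 (0.74 log units; beyond the scatter) lies beyond the scatter, as does a 6.7-fold lower number from compound 1 to compound 3 (0.82 log units; beyond the scatter). Compounds 1 and 2 are not separated by more than the scatter, since a 1.2-fold lower number from compound 1 to compound 2 (0.08 log units; within the scatter).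

Compound 4, `CCCCCCNS(=O)(=O)NC(=O)Nc1c(C(C)C)cccc1C(C)C`, has not yet been measured. It differs from compound 3 in one place: hexylamino in place of diallylamino on a sulfonyl sulfur. Within the data shown here, two measured steps bear on this change, both leading to compound 3 from a sulfonyl nitrogen that carries a hydrogen-bond donor or a ring: a 6.7-fold lower number from compound 1 to compound 3 (0.82 log units; beyond the scatter) and a 5.6-fold lower number from compound 2 to compound 3 (0.74 log units; beyond the scatter). Among the measured compounds shown here, in compound 4 the diallylamino group is again replaced by a group with one hydrogen-bond donor, so a step back toward the numbers of compounds 1 and 2 is expected, though no measured pair shows a hexyl chain in this place, and how much its length matters is unknown. Compound 4 is therefore expected to give 8000 nM in this assay, within a range of 2500 nM to 25000 nM. This estimate corresponds to an expected step of a 3.0-fold higher number from compound 3 to compound 4 (0.47 log units; beyond the scatter).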

Compound 4, half-maximal inhibitory concentration: 8100 nM
For compound 4 the middle estimate is 1.0-fold (0.01 log units) below the measured one, and the stated range covers the measured number.
By their numbers in this assay, from the lowest: compound 3; then compounds 4, 2 and 1 (each within the scatter of the next, the first and the last beyond it).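

In this assay hexylamino and diallylamino have the same count of heavy atoms and neither carries a ring, yet the exchange gives a 3.0-fold higher number from compound 3 to compound 4 (0.48 log units; beyond the scatter) and so shows that the size of the group on the sulfonyl sulfur, counted in heavy atoms, does not alone set the number; the two groups differ in the hydrogen-bond donor of hexylamino and the double bonds of diallylamino. The chain on the sulfonamide nitrogen also matters to a modest degree, since a 2.2-fold lower number from compound 1 to compound 4 (0.35 log units; beyond the scatter) lies beyond the scatter, whereas a 1.9-fold lower number from compound 2 to compound 4 (0.27 log units; within the scatter) stays within it and leaves hexylamino and pyrrolidin-1-yl unseparated. Nothing measured here accounts for these steps.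

The compounds shown leave open whether dipropylamino, which keeps two chains on the nitrogen but has no double bonds, would match diallylamino in compound 3 or fall back toward compound 4. They also leave open whether a longer chain such as octylamino would lower the number further or whether the trend from isopropyl to hexyl stops there.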